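A few compounds are considered here, and "the series" means these few. Any claim that something is new, unique, unknown or untested is made for them only; others in the source may bear on it.

Measured compounds in a functional assay on MCF7 cells (Homo sapiens) for antiproliferative activity; a lower number here means a stronger inhibitor, a higher number a weaker inhibitor:
compound 1, `CCC(CC)Cn1c(Cc2cc(OC)c(OC)c(OC)c2)nc2c(N)ncnc21`, 158000 nM
compound 2, `CC#CCCn1c(Cc2cc(OC)c(OC)c(OC)c2)nc2c(N)nc(F)nc21`, 37200 nM
compound 3, `CCCCn1c(Cc2cc(OC)c(OC)c(OC)c2Cl)nc2c(N)ncnc21`, 19100 nM

Compound 1 stands highest of the three numbers: compound 2 and compound 3 both give lower values, and each gap lies beyond the scatter. Among the measured compounds shown here, compound 2 and compound 3 carry shorter chains on the aromatic nitrogen than compound 1 but also differ from it in their ring substituents, so no single-change step is available among the measured compounds.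

Compound 4, `C/C=C/Cn1c(Cc2cc(OC)c(OC)c(OC)c2)nc2c(N)ncnc21`, is not yet measured. It differs from compound 1 in one place: prop-1-en-1-yl in place of pentan-3-yl on a saturated chain carbon bound to an aromatic nitrogen.

With a shorter chain entering, for compound 4 the expected step in this assay is a 2.6-fold lower number from compound 1 to compound 4 (0.42 log units; beyond the scatter). The estimate for compound 4 is 60000 nM, within 20000 nM to 180000 nM.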

Compound 4, half-maximal inhibitory concentration: 51300 nM
Compound 4: middle estimate off by 1.2-fold (0.07 log units), on the high side, within the range that was stated.
By their numbers in this assay, from the lowest: compounds 3, 2 and 4 (each within the scatter of the next, the first and the last beyond it); then compound 1.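

In this assay the chain on the aromatic nitrogen can now be read on its own: with the rest of the structure held, prop-1-en-1-yl in place of pentan-3-yl gives a modest step (a 3.1-fold lower number from compound 1 to compound 4 (0.49 log units; beyond the scatter)). This position therefore moves the number beyond the scatter without any change in the ring substituents. No measurement shown gives a cause for this step.

Going by these compounds, the change shortens the chain and adds a double bond together, so the share of each stays open. Also open, on these data alone, is whether a chain ending in an amine or a carboxylic acid would give a lower number at this position.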